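Biphenyl removal in the pyrrolidinyl thioether series

This account rests on a few compounds, and the source may have more. Where it says the series, first, only, none or still open, it means among the compounds named here.

Measured in a functional assay on A549 cells (Homo sapiens) for cytotoxicity, read by MTT assay, with a stated time of 48 h; a higher number here means a weaker inhibitor, a lower number a stronger inhibitor:
- compound 1 `O=C(CC1c2ccccc2N=C(SCCCCCN2CCCC2)N1c1ccc(-c2ccc(F)cc2)cc1)NCc1ccccc1`: 17800 nM
- compound 2 `O=C(CC1c2ccccc2N=C(SCCCCCN2CCCC2)N1c1ccccc1)NCc1ccc(F)cc1`: 89900 nM
- compound 3 `O=C(CC1c2ccccc2N=C(SCCCCCN2CCCC2)N1c1ccc(-c2ccccc2)cc1)NCc1ccccc1`: 14900 nM

Compound 3 at 14900 nM lies within the scatter of compound 1 at 17800 nM, and both values are well under that of compound 2 at 89900 nM.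

Compound 4 `O=C(CC1c2ccccc2N=C(SCCCCCN2CCCC2)N1c1ccccc1)NCc1ccccc1` has hydrogen in place of phenyl on an aromatic carbon, para to a large group, so that 4-phenylphenyl becomes phenyl: hydrogen in place of phenyl on an aromatic carbon.

For the measured compounds named here, the one measured step, a 1.2-fold lower number from compound 1 to compound 3 (0.08 log units; within the scatter), is an exchange of fluoro for hydrogen and gives no direct size for losing a phenyl. Compound 2 is the closer guide, since it carries the same phenyl as compound 4 and differs from it by one fluoro on an aromatic carbon. Given compound 2 at 89900 nM, a step to a higher number beyond the scatter is expected in this assay. The estimated step is a 4.4-fold higher number from compound 3 to compound 4 (0.64 log units; beyond the scatter). The estimate for compound 4 is 65000 nM, with an expected range of 30000 nM to 130000 nM.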

Compound 4, half-maximal inhibitory concentration: 98100 nM
Compound 4: middle estimate off by 1.5-fold (0.18 log units), on the low side; the range from low to high includes it.
By their numbers in this assay, from the lowest: compounds 3 and 1 (each within the scatter of the next); then compounds 2 and 4 (each within the scatter of the next).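

In this assay, the outer aromatic ring of the 4-phenylphenyl group now has a direct reading: its loss gives a 6.6-fold higher number from compound 3 to compound 4 (0.82 log units; beyond the scatter), and loss of the 4-fluorophenyl group gives a 5.5-fold higher number from compound 1 to compound 4 (0.74 log units; beyond the scatter). Both steps lie beyond the scatter, so compounds carrying an outer ring at this place give the lower numbers among the pairs that can be compared. Hydrogen in place of fluoro stays small on the core without the outer ring, with a 1.1-fold higher number from compound 2 to compound 4 (0.04 log units; within the scatter), and the two fluoro steps agree: the same change on two cores in this assay, a 1.2-fold lower number (0.08 log units; within the scatter) from compound 1 to compound 3 and a 1.1-fold higher number (0.04 log units; within the scatter) from compound 2 to compound 4, 1.3-fold (0.12 log units) apart, within the scatter of two such steps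

Going by these compounds, it remains open whether a whole aromatic ring is needed at this place, or whether a methyl, a methoxy or a cyclohexyl group would serve as well. The compounds shown also leave open whether an outer ring bearing an amine or a carboxylic acid would hold the lower number.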